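This account rests on a few compounds, and the source may have more. Where it says the series, first, only, none or still open, it means among the compounds named here.

Measured so far:
compound 1, `N[C@H]1CC[C@H](Nc2c(C(=O)NCc3ccc(Oc4ccccc4)cc3)nc(Br)c3cccnc23)CC1` — in a functional assay on HCT-116 cells (Homo sapiens) for cytotoxicity, read by MTT assay, with a stated time of 72 h (a higher number here means a weaker inhibitor, a lower number a stronger inhibitor), compound 1 gives "not determined" (no result reported).
compound 2, `NCCCNc1c(C(=O)NCc2ccc(F)cc2)ncc2cccnc12` — compound 2 gives only a limit in this assay, > 10000 nM.

Among the measured compounds shown here, compound 1 therefore stands nowhere on a scale: no number for it exists in this assay, and the single further value in the set is a limit rather than a measurement, as noted in the limit of > 10000 nM in this assay, at which 1 of the 2 values shown sits. For the measured compounds named here, no step between two measured compounds can be drawn, so the series offers no measured change to lean on.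

The compound still to be measured is compound 3, `N[C@H]1CC[C@H](Nc2c(C(=O)NCc3ccc(F)cc3)nc(Br)c3cccnc23)CC1`. Its difference from compound 1 is fluoro in place of phenoxy on an aromatic carbon, a fluoro in place of phenoxy on an aromatic carbon. No evidence here bears on the size or direction of such a change in this assay; nothing beyond the usual scatter can be expected or excluded from the data at hand, and with compound 1 itself unmeasured the starting point is open.

For compound 3 the estimate in this assay is 5000 nM, with an expected range of 500 nM to 30000 nM, and a real chance that only a limit is returned.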

Compound 3, half-maximal inhibitory concentration: 7000 nM
Compound 3: middle estimate off by 1.4-fold (0.15 log units), on the low side; low and high end bracket the measured number.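

No step can be read from compound 1 to compound 3: in this assay compound 1 gives "not determined" (no result reported), so the value of compound 3 has no partner. Among the compounds shown here, the only other value shown is a limit: the limit of > 10000 nM in this assay, at which 1 of the 3 values shown sits. The compounds shown leave open how fluoro in place of phenoxy changes the read-out in this assay.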